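This account rests on a few compounds, and the source may have more. Where it says the series, first, only, none or still open, it means among the compounds named here.

Three related nucleoside analogues have been tested in a functional assay on L5178Y cells (Mus musculus) for antiproliferative activity; a lower number here means a stronger inhibitor, a higher number a weaker inhibitor. Compound 1, `Nc1ccn([C@@H]2O[C@H](CO)[C@H](F)[C@H]2O)c(=O)n1`, carries a fluoro on its sugar ring and a cytosine base without a fluorine; in this assay compound 1 gives 37 ug/mL. Compound 2, `Nc1nc(=O)n(C2OC(CO)C(Cl)C2O)cc1F`, has a chloro on the sugar ring and a fluorine on the base; in this assay compound 2 gives 1 ug/mL. Compound 3, `CS(=O)(=O)O[C@@H]1[C@@H](O)[C@H](n2cc(F)c(N)nc2=O)O[C@@H]1CO`, replaces the chloro of compound 2 with a methanesulfonyloxy group; in this assay compound 3 gives 0.05 ug/mL.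

Of the three numbers, compound 2 stands second highest: compound 3 sits well below it, beyond the usual scatter, while compound 1 sits well above it, also beyond the scatter. So compound 2 is the middle of the series.

Compound 4, `Nc1nc(=O)n(C2OC(CO)C(Br)C2O)cc1F`, differs from compound 2 by bromo in place of chloro on a saturated ring carbon. The change is the smallest kind possible: one halogen for another, with no change in ring count, in donors, in acceptors or in charge. Going by the values given here, no pair of measured compounds shows this exact swap, so the step from chloro to bromo has no direct precedent here. Given how small the change is, no step beyond the scatter is expected, in either direction. The expected step from compound 2 is no change at the digits printed from compound 2 to compound 4 (within the scatter).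

Compound 4 is therefore estimated at 1 ug/mL, with a likely range from 0.3 ug/mL to 3 ug/mL.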

Compound 4, concentration for 50% inhibition: 0.06 ug/mL
For compound 4 the middle estimate is 17-fold (1.22 log units) above the measured one; the measured number lies below the stated range.
By their numbers in this assay, from the lowest: compounds 3 and 4 (each within the scatter of the next); then compound 2; then compound 1.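

In this assay, the step of a 17-fold lower number from compound 2 to compound 4 (1.22 log units; beyond the scatter) shows that this saturated ring carbon, which bears a hydroxy-bearing ring atom on one side and a hydroxymethyl-bearing ring atom on the other, does not treat chloro and bromo as interchangeable. One halogen replaces another with no change in rings, hydrogen-bond donors, hydrogen-bond acceptors or net charge, and the number still moves beyond the scatter, so even a single-atom exchange here can matter greatly. The earlier compounds could not show this, as no two of them formed a step that differs in one place, and nothing available explains why bromo gives the lower number.

Compound 1 carries a fluoro on the sugar ring but also lacks the fluorine on the base, so its value cannot be set directly against those of compound 2 or compound 4. The compounds shown leave open how iodo, an amine or a methoxy group would behave on this same ring carbon with the fluorine on the base kept in place.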